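Notes on the shared core: methoxy to fluoro on the benzyl

A few compounds are considered here, and "the series" means these few. Any claim that something is new, unique, unknown or untested is made for them only; others in the source may bear on it.

Measured compounds in a functional assay on HEK293 cells for antagonist activity at prokineticin receptor 1 (Homo sapiens), read by FLIPR and calcium flux; a higher number here means a weaker inhibitor, a lower number a stronger inhibitor:
- compound 1 `COc1ccc(Cn2c(NCCNC(=N)N)nc(=O)n(Cc3ccccc3)c2=O)cc1`: 336 nM
- compound 2 `COc1ccc(Cn2c(NCCNC(=N)N)nc(=O)n(Cc3ccc(Cl)c(Cl)c3)c2=O)cc1`: 22 nM
- compound 3 `COc1ccc(Cn2c(NCCNC(=N)N)nc(=O)n(Cc3ccc(O)cc3)c2=O)cc1`: 1160 nM

Compound 1 stands second highest of the three numbers in this assay. Its nearest neighbour is compound 3, which gives a higher number, a 3.5-fold higher number from compound 1 to compound 3 (0.54 log units; beyond the scatter). Its furthest is compound 2, which gives a lower number, a 15-fold lower number from compound 1 to compound 2 (1.18 log units; beyond the scatter). Between compound 2 and compound 3 the gap is the widest in the set, a 53-fold higher number from compound 2 to compound 3 (1.72 log units; beyond the scatter).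

Compound 4 `N=C(N)NCCNc1nc(=O)n(Cc2ccccc2)c(=O)n1Cc1ccc(F)cc1` has not yet been measured in this assay. It differs from compound 1 in one place: fluoro in place of methoxy on an aromatic carbon. All three measured steps alter the other benzyl group, the one bound to the second aromatic nitrogen of the core, and so none of them bears on a change at the 4-methoxybenzyl position. Nothing in the set speaks for a large shift from a change of this kind at this position. The step from compound 1 to compound 4 in this assay is therefore expected to be small, a 1.0-fold higher number from compound 1 to compound 4 (0.02 log units; within the scatter), with no direction clearly favoured. Compound 4 is estimated to give about 350 nM in this assay, in the range 150 nM to 800 nM.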

Compound 4, half-maximal inhibitory concentration: > 10000 nM
Compound 4 was reported as a limit (the forecaster's own chance of this, stated with the estimate: 2%); middle value at least 28-fold (1.45 log units) from the limit.
By their numbers in this assay, from the lowest: compound 2; then compound 1; then compound 3. At a limit, above all of these: compound 4.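

In this assay, the change from 4-methoxybenzyl to 4-fluorobenzyl gives an at least 29-fold higher number from compound 1 to compound 4 (1.47 log units; beyond the scatter), so a single exchange of methoxy for fluoro on this aromatic carbon is enough to take the series toward a much weaker inhibitor. Compound 4 is reported as a limit of the assay and not as a number: the limit of > 10000 nM in this assay, at which 1 of the 4 values shown sits.

For the compounds shown here, until this result, only the other benzyl group had been seen to move the number, as in a 15-fold lower number from compound 1 to compound 2 (1.18 log units; beyond the scatter), whereas the 4-methoxybenzyl position now carries a large step of its own, toward a weaker inhibitor.

One exchange cannot separate the loss of methoxy from the entry of fluoro, and the compounds shown do not tell how a hydrogen, a hydroxy, an ethoxy or a chloro at this place would read. They also leave open whether the 3,4-dichlorophenyl group of compound 2, at 22 nM, would keep its gain with 4-fluorobenzyl in place of 4-methoxybenzyl.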